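The source may report more compounds than this note shows. Statements on the series, on what has been measured and on what is new or still open speak of the compounds shown alone.

Compounds 1 to 3 share one core and differ in the group on a single aromatic carbon. In a functional assay on HeLa S3 cells (Homo sapiens) for antiproliferative activity, read by XTT assay, with a stated time of 72 h (on this read-out higher numbers stand for weaker inhibition and lower numbers for stronger inhibition), compound 1 `CNc1ncnc2c1c(-c1ccco1)cn2[C@@H]1O[C@H](CO)[C@@H](O)[C@H]1O`, with furan-2-yl, gives 5000 nM. Compound 2 `CNc1ncnc2c1c(-c1cccs1)cn2[C@@H]1O[C@H](CO)[C@@H](O)[C@H]1O`, with thiophen-2-yl, reads > 20000 nM, which is a limit. Compound 3 `CNc1ncnc2c1c(-c1cc3ccccc3o1)cn2[C@@H]1O[C@H](CO)[C@@H](O)[C@H]1O`, with 1-benzofuran-2-yl, reads > 20000 nM, also a limit. That is the limit of > 20000 nM in this assay, at which 2 of the 3 values shown sit. Compound 4 `CNc1ncnc2c1c(I)cn2[C@@H]1O[C@H](CO)[C@@H](O)[C@H]1O` arises from compound 3 by iodo in place of 1-benzofuran-2-yl on an aromatic carbon. Within the data shown here, no measured step brings in iodo, and a step that the two limits leave unreadable from compound 2 to compound 3 tells nothing. Because an at least 4.0-fold higher number from compound 1 to compound 3 (0.60 log units; beyond the scatter) and an at least 4.0-fold higher number from compound 1 to compound 2 (0.60 log units; beyond the scatter) show that this carbon's group can shift the read-out, a modest move toward stronger inhibition is expected in this assay. The expected step is an at least 2.5-fold lower number from compound 3 to compound 4 (0.39 log units; beyond the scatter). For compound 4 the estimate is 8000 nM, with an expected range of 1500 nM to 30000 nM.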

Compound 4, half-maximal inhibitory concentration: > 20000 nM
Compound 4 ended at the assay's limit (the forecaster's own chance of this, stated with the estimate: 40%); middle value at least 2.5-fold (0.39 log units) away from the limit.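

In this assay, among these compounds, iodo in place of furan-2-yl gives an at least 4.0-fold higher number from compound 1 to compound 4 (0.60 log units; beyond the scatter), so a group with no ring on this carbon also leaves compound 1 as the only one with a readable value. Compound 4 reads > 20000 nM, which is a limit. The steps among compound 2, compound 3 and compound 4 cannot be read, and the limit now holds most of the series: the limit of > 20000 nM in this assay, at which 3 of the 4 values shown sit.

From the compounds shown here alone, how far these compounds lie past the limit stays open. So does whether an amine, a methyl or a 1,3-oxazol-2-yl group on this carbon would match or improve on furan-2-yl.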